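Methoxy for Methyl on a Serotonin Receptor Ligand

A few compounds are considered here, and "the series" means these few. Any claim that something is new, unique, unknown or untested is made for them only; others in the source may bear on it.

Compound 1 `Cc1cc(N2CCNCC2)c2c(c1)N(S(=O)(=O)c1ccccc1F)CCO2`: 0.398 nM
Compound 2 `Cc1cc(N2CCNCC2)c2c(c1)N(S(=O)(=O)c1ccccc1C#N)CCO2`: 2 nM

In an assay on HEK293 cells for displacement of a labelled ligand from 5-hydroxytryptamine receptor 6 (Homo sapiens) (a higher number here means a weaker inhibitor, a lower number a stronger inhibitor), compound 1 gives 0.398 nM, the lowest of the two numbers shown. Among the compounds with values here, compound 2 gives 2 nM, and the only measured step, a 5.0-fold higher number from compound 1 to compound 2 (0.70 log units; beyond the scatter), concerns a different position on the sulfonyl-bearing ring. Compound 3 `COc1cc(N2CCNCC2)c2c(c1)N(S(=O)(=O)c1ccccc1F)CCO2` differs from compound 1 by methoxy in place of methyl on an aromatic carbon. Within the data shown here, no measured step touches this change, so nothing here supports a large shift in either direction. For compound 3 a step within the scatter is expected, a 1.5-fold higher number from compound 1 to compound 3 (0.18 log units; within the scatter). Compound 3 is therefore estimated at 0.6 nM, between 0.2 nM and 2 nM.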

Compound 3, inhibition constant: 0.159 nM
Beside the measured number, compound 3's estimate is 3.8-fold (0.58 log units) above it; the whole stated range lies above it.
By their numbers in this assay, from the lowest: compound 3; then compound 1; then compound 2.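

In this assay, methoxy in place of methyl gives a 2.5-fold lower number from compound 1 to compound 3 (0.40 log units; beyond the scatter). Within the data shown here, this is the first measured sign that the aromatic carbon carrying this group affects the number, as the earlier step concerned only the sulfonyl-bearing ring. Though modest, the change lies beyond the scatter, so the position tolerates the extra oxygen without any loss here.

On these data alone, whether an ethoxy group or an amine at this carbon would shift the number further remains open, as does whether methoxy would give a similar step alongside the nitrile of compound 2. No measurement shown here explains the step.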